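The compounds below may be only part of what the source reports. "The series", "measured", "known", "first", "only" and "open" are said of these compounds alone.

Compound 1 `COc1cc(OC)c(OC)cc1/C=C/COC(=O)/C=C/c1ccc(OC)c(OC)c1`: 0%
Compound 2 `COc1cc(OC)c(OC)cc1/C=C/COC(=O)/C=C/c1ccc(F)cc1`: 0%
Compound 3 `COc1cc(OC)c(OC)cc1/C=C/COC(=O)/C=C/c1ccc(Br)cc1`: 25%

In a functional assay on the whole organism (strain Kunming) with Mus musculus as the target, with a stated time of 0.5 h, at a dose of 300 mg/kg by the intraperitoneal route (on this read-out lower numbers stand for a stronger effect and higher numbers for a weaker effect at the one dose given), compound 2 stands level with compound 1, the two together the lowest of the three numbers, while compound 3 lies a number 25 percentage points higher from compound 2 to compound 3 (beyond the scatter). Compound 4 `COc1ccc(/C=C/C(=O)OC/C=C/c2cc(OC)c(OC)cc2OC)cc1` differs from compound 2 by methoxy in place of fluoro on an aromatic carbon. Among the compounds with values here, no measured step swaps fluoro for methoxy directly. The nearest guide is no change at the digits printed from compound 1 to compound 2 (within the scatter), where a ring carrying two methoxy groups gave the same number as the fluoro ring; the only rise seen, a number 25 percentage points higher from compound 2 to compound 3 (beyond the scatter), came with bromo, which compound 4 does not carry. A methoxy on this ring is therefore expected to leave the number where it is, giving an expected step of no change at the digits printed from compound 2 to compound 4 (within the scatter). Compound 4 is thus estimated at 0%, within 0% to 15%.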

Compound 4, a percentage reported as activity, at one dose (the size of the read-out at that dose, not a potency): 0%
Estimate against measurement, compound 4: no gap at the digits printed; low and high end bracket the measured number.
By their numbers in this assay, from the lowest: compounds 1, 2 and 4 (each within the scatter of the next); then compound 3.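

In this assay a 4-methoxyphenyl ring reads the same as a 4-fluorophenyl ring (no change at the digits printed from compound 2 to compound 4 (within the scatter)), and the ring with one methoxy matches the ring with two (no change at the digits printed from compound 1 to compound 4 (within the scatter)). Methoxy in place of bromo gives a clear shift (a number 25 percentage points lower from compound 3 to compound 4 (beyond the scatter)), so among these four compounds bromo alone stands apart, with compound 3 the only exception to the shared reading. No measured evidence explains why bromo differs. On these data alone, whether chloro, an amine or a carboxylic acid on this ring would read like bromo or like methoxy remains open.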